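The source may report more compounds than this note shows. Statements on the series, on what has been measured and on what is new or still open speak of the compounds shown alone.

Measured so far:
compound 1, `N=C(N)NCCC[C@@H]1NC(=O)CNC(=O)C[C@@H](C(=O)O)NC(=O)[C@@H](c2ccccc2)NC(=O)[C@@H](CCCCN)NC1=O`: 8.7 nM
compound 2, `N=C(N)NCCC[C@@H]1NC(=O)CNC(=O)C[C@@H](C(=O)O)NC(=O)[C@@H](c2ccccc2)NC(=O)[C@H](Cc2c[nH]c3ccccc23)NC1=O`: 72 nM

In an assay on a protein complex for binding affinity to integrin alpha-5/beta-1 (Homo sapiens), read by ELISA (on this read-out lower numbers stand for stronger inhibition and higher numbers for weaker inhibition), compound 1 gives 8.7 nM, while compound 2 gives 72 nM; compound 2 thus stands with the highest of the two numbers in this assay, and the gap between compound 2 and compound 1 lies beyond the scatter. Among the compounds with values here, no step between compounds differing in a single place has been measured, so the two values are stated side by side without being traced to one change.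

Compound 3, `N=C(N)NCCC[C@@H]1NC(=O)CNC(=O)C[C@@H](C(=O)O)NC(=O)[C@@H](c2ccccc2)NC(=O)[C@@H](Cc2c[nH]c3ccccc23)NC1=O`, has not yet been measured. The difference from compound 2 is the two compounds have the same atoms and bonds; at least one stereo element is drawn with a configuration in one of them and without one in the other: 1 of 5 stereo elements differ; a stereocentre at a saturated ring carbon is drawn S in compound 2 and R in compound 3. Inversion of one stereocentre in a cyclic peptide can move this assay either way, and no measured pair here shows such a step; compound 3 is therefore expected with a wide range. The estimate for compound 3 in this assay is 30 nM, between 5 nM and 200 nM, which means an expected step from compound 2 to compound 3 of a 2.4-fold lower number from compound 2 to compound 3 (0.38 log units; beyond the scatter).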

Compound 3, half-maximal inhibitory concentration: 5.5 nM
Estimate against measurement, compound 3: 5.5-fold (0.74 log units) above, within the range that was stated.
By their numbers in this assay, from the lowest: compounds 3 and 1 (each within the scatter of the next); then compound 2.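

In this assay, the configuration at this saturated ring carbon matters on its own: with atoms and bonds the same, going from S to R gives a 13-fold lower number from compound 2 to compound 3 (1.12 log units; beyond the scatter). With the R configuration, 1H-indol-3-yl in place of 3-aminopropyl gives a 1.6-fold lower number from compound 1 to compound 3 (0.20 log units; within the scatter), so the two groups cannot be told apart here. How firmly the large step can be tied to a full inversion at this carbon rests on how the two structures are drawn: the fact that one of compounds 2 and 3 is drawn with a defined configuration and the other without, at the place where they differ

The compounds shown leave open how the 3-aminopropyl chain behaves when its carbon has the opposite configuration. They also leave open whether a carboxylic acid or a benzyl group at this place would respond to inversion in the same way.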